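The source may report more compounds than this note shows. Statements on the series, on what has been measured and on what is new or still open speak of the compounds shown alone.

Measured compounds:
compound 1 `O=[N+]([O-])c1ccc(CSc2nnc(-c3ccncc3)n2-c2ccccc2)cc1`, 22800 nM
compound 2 `O=C(CSc1nnc(-c2ccncc2)n1-c1ccccc1)N/N=C/c1ccc([N+](=O)[O-])cc1`, 15300 nM

In a functional assay on MCF7 cells (Homo sapiens) for inhibition, read by MTT assay, with a stated time of 48 h (on this read-out lower numbers stand for stronger inhibition and higher numbers for weaker inhibition), compound 1 gives 22800 nM, and compound 2 gives 15300 nM. Compound 2 stands at one end of the two numbers shown, with compound 1 its only neighbour, and the gap between them lies within the scatter, so neither can be set apart from the other in this assay. Going by the values given here, no step between measured compounds is known here, so the shared core has not yet been followed through a single change.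

Compound 3 `O=C(CSc1nnc(-c2ccncc2)n1-c1ccccc1)N/N=C/c1cc(Br)cc(Br)c1O` is the untested compound. It differs from compound 2 as follows: 3,5-dibromo-2-hydroxyphenyl in place of 4-nitrophenyl on a carbon with a double bond to nitrogen. With nothing measured on this change, the expectation for compound 3 rests on compound 2 alone, at 15300 nM, and a modest step is expected, a 1.7-fold lower number from compound 2 to compound 3 (0.23 log units; within the scatter), towards stronger inhibition but of a size that may not exceed the scatter. Compound 3 is therefore estimated at 9000 nM, in the range 3000 nM to 30000 nM.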

Compound 3, half-maximal inhibitory concentration: 8440 nM
For compound 3 the middle estimate is 1.1-fold (0.03 log units) above the measured one; the range from low to high includes it.
By their numbers in this assay, from the lowest: compounds 3, 2 and 1 (each within the scatter of the next, the first and the last beyond it).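

With compound 3 the group on a carbon with a double bond to nitrogen is exchanged for the first time among the compounds shown, and in this assay the exchange gives a 1.8-fold lower number from compound 2 to compound 3 (0.26 log units; within the scatter) and so does not set the two compounds apart. 3,5-Dibromo-2-hydroxyphenyl, which has 1 hydrogen-bond donor where 4-nitrophenyl has none, can thus stand in place of 4-nitrophenyl, with 9 heavy atoms in each, without a difference that can be separated from the scatter. No evidence at hand bears on this result.

On these data alone, the exchange removes the nitro group and brings in the bromines and the hydroxyl together, so the share of each stays open. Also open, as far as these compounds go, is whether a plain phenyl, or a phenyl carrying an amine or a carboxylic acid, would read beyond the scatter from compound 2.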